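The source may report more compounds than this note shows. Statements on the series, on what has been measured and on what is new or still open speak of the compounds shown alone.

Cytotoxicity in an ADME assay on TERT-RPE1 cells (Homo sapiens) for cytotoxicity, read by MTT assay, with a stated time of 72 h (on this read-out higher numbers stand for weaker inhibition and lower numbers for stronger inhibition), is known for three members of the series. Going by the values given here, compound 1 `COc1ccc(/C=C2/CN(C)/C(=N/c3ccc(C)cc3)S2)cc1` gives 65700 nM in this assay, the only numerical value among them. Compound 2 `COc1ccc(/C=C2\S/C(=N\c3ccc(F)cc3)N(C)C2=O)cc1` gives > 100000 nM, which is a limit of this assay rather than a number. Compound 3 `COc1ccc(/C=C2\S/C(=N\c3ccc(OC)cc3)N(C)C2=O)cc1` likewise gives > 100000 nM, again a limit. The step that the two limits leave unreadable from compound 2 to compound 3 therefore cannot be sized because both values sit at the limit of > 100000 nM in this assay, at which 2 of the 3 values shown sit. Compound 4 `COc1ccc(/C=C2/CN(C)/C(=N/c3ccc(Br)cc3)S2)cc1` differs from compound 1 by bromo in place of methyl on an aromatic carbon. Among the compounds with values here, no measured step concerns this change, so nothing supports a shift beyond the scatter in either direction. Compound 4 is expected to remain close to compound 1, the step of a 1.1-fold lower number from compound 1 to compound 4 (0.04 log units; within the scatter) being an estimate only. Compound 4 is thus estimated at 60000 nM, within 20000 nM to 150000 nM.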

Compound 4, half-maximal inhibitory concentration: 61300 nM
Compound 4: middle estimate off by 1.0-fold (0.01 log units), on the low side, within the range that was stated.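

In this assay, going by these compounds alone, the change from 4-methylphenyl to 4-bromophenyl gives a 1.1-fold lower number from compound 1 to compound 4 (0.03 log units; within the scatter), the first readable step at this position, on an aromatic carbon para to a large group. Within the data shown here, the only earlier step at this position, from fluoro to methoxy, cannot be read. No data shown bear on a cause for the new step.

From the compounds shown here alone, whether an amine or a carboxylic acid here would move the number beyond the scatter remains open. Also open, going by these compounds, is the role of the carbonyl in the core of compound 2 and compound 3, which differ from compound 1 in more than one place.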